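The compounds below may be only part of what the source reports. "The series", "measured", "known", "first", "only" and "open" are said of these compounds alone.

In an ADME assay on Vero cells (Chlorocebus sabaeus) for cytotoxicity, read by crystal violet staining (a higher number here means that more compound is tolerated, a lower number that less compound is tolerated), the three measured compounds all sit at the edge of what the assay can report. Compound 1 `Clc1cccc(/N=N/N2CCCC2)c1` gives >= 100000 nM, which is a limit of the assay rather than a number. Compound 3 `Fc1ccc(F)c(/N=N/N2CCCC2)c1` gives > 100000 nM, again a limit of the assay. Compound 2 `c1ccc(/N=N/N2CCN(c3ccccc3)CC2)cc1` gives >= 100000 nM in this assay, once more a limit and not a number. Compound 2 thus stands alongside compound 1 and compound 3 at a limit; the limit of >= 100000 nM in this assay, at which 2 of the 3 values shown sit, holds two of the three readings and the limit of > 100000 nM in this assay, at which 1 of the 3 values shown sits, the third, so no number separates any of them.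

Compound 4 `CN1CCN(/N=N/c2ccccc2)CC1` has not yet been measured in this assay. It differs from compound 2 by methyl in place of phenyl on an amine nitrogen in a ring. No measured pair differs in a single place, so no step of known size stands behind this change, and the shared readings at the limit give no reason to expect a step beyond the scatter in either direction. Compound 4 is therefore expected to give 100000 nM, within 50000 nM to 200000 nM. That expectation means a step of a number no higher from compound 2 to compound 4 (the limit leaves the size open), with the assay most likely reporting only a limit again.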

Compound 4, half-maximal cytotoxic concentration: 45000 nM
Compound 4: middle estimate off by 2.2-fold (0.35 log units), on the high side; measured number below the stated range.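

In this assay, methyl in place of phenyl on an amine nitrogen in a ring gives an at least 2.2-fold lower number from compound 2 to compound 4 (0.34 log units; beyond the scatter). Among the compounds shown here, this shows that the group on this nitrogen can move the reading beyond the scatter, which the earlier compounds, all resting at limits, could not show. Compound 2 gives only a limit and not a number, so the true size of the step stays open on its large side: the limit of >= 100000 nM in this assay, at which 2 of the 4 values shown sit.

This one pair cannot tell whether the lower number follows the loss of the phenyl ring or the arrival of the methyl, and it gives no cause for the change. It also leaves open where an ethyl or benzyl group on the same nitrogen would fall, and whether the step would hold with a substituted ring on the other side of the chain.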